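A Chloro Step from a Limit

This account rests on a few compounds, and the source may have more. Where it says the series, first, only, none or still open, it means among the compounds named here.

Measured in an ADME assay on Vero cells (Chlorocebus sabaeus) for cytotoxicity, read by CellTiter-Glo and ATP content, with a stated time of 72 h (on this read-out higher numbers stand for lower toxicity in this test and lower numbers for higher toxicity in this test), both values are limits:
- compound 1 `Nc1c(C2=NCCN2)cnn1-c1ccccc1`: > 500000 nM
- compound 2 `Nc1c(C2=NCCCN2)cnn1-c1ccccc1`: > 500000 nM

Neither compound has an exact number yet. Compound 2 stands only at a limit, > 500000 nM. The two results sit together at the limit of > 500000 nM in this assay, at which 2 of the 2 values shown sit. For the measured compounds named here, the one measured change is a step that the two limits leave unreadable from compound 1 to compound 2, so it gives no size to carry forward.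

Compound 3 `Nc1c(C2=NCCCN2)cnn1-c1ccc(Cl)cc1` differs from compound 2 by chloro in place of hydrogen on an aromatic carbon. Going by the values given here, no measured step shows what this kind of change does in this assay, so the expectation has little to rest on. Only a small move toward a lower number is expected, and another limit would be no surprise. The expected change is an at least 1.2-fold lower number from compound 2 to compound 3 (0.09 log units; that floor lies within the scatter). For compound 3 the estimated value is 400000 nM, with an expected range from 150000 nM to 500000 nM.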

Compound 3, half-maximal cytotoxic concentration: > 500000 nM
Compound 3: no number, only a limit; the forecaster's own chance of this, stated with the estimate: 60%; at least 1.2-fold (0.09 log units) between middle value and limit.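

Compound 2 and compound 3 both give only a limit in this assay, so the step between them cannot be read, and chloro in place of hydrogen gets no size. The compounds shown leave open what exact value any of them would have, and whether any of their changes alters that value, as all of them sit at one limit: the limit of > 500000 nM in this assay, at which 3 of the 3 values shown sit.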